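The source may hold more compounds than are shown below. What is called first, only, known or untested is meant among the compounds shown, and "the series" means these compounds.

Measured compounds in this series:
- compound 1 `O=S(=O)(Nc1ccc(-c2nc3ccccc3o2)cc1)c1cccc(O)c1`: > 63000 nM (a limit of the assay)
- compound 2 `O=S(=O)(Nc1ccc(-c2nc3ccccc3o2)cc1)c1ccc(F)c(C(F)(F)F)c1`: > 63000 nM (a limit of the assay)
- compound 3 `O=S(=O)(Nc1ccc2oc(-c3ccccc3)nc2c1)c1ccc(F)c(C(F)(F)F)c1`: > 63000 nM (a limit of the assay)

In an assay on isolated protein for inhibition of malate dehydrogenase, mitochondrial (Sus scrofa), with stated times of 45 min and 30 min (on this read-out lower numbers stand for stronger inhibition and higher numbers for weaker inhibition), compound 1 gives > 63000 nM, which is a limit of the assay and not a number. In this assay compound 2 gives > 63000 nM, again a limit. Compound 3 gives > 63000 nM, also a limit. The one thing the series shows so far is the limit of > 63000 nM in this assay, at which 3 of the 3 values shown sit: every value reported stops at the same limit, so compound 1 cannot be placed above or below compound 2 or compound 3, and nothing in these numbers separates the three.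

Compound 4 `O=S(=O)(Nc1ccc(-c2nc3ccccc3o2)cc1)c1ccc(O)cc1` differs from compound 1 by 4-hydroxyphenyl in place of 3-hydroxyphenyl on a sulfonyl sulfur. Going by the values given here, no step between two measured compounds is known, so there is no measured size of change to lean on for this pair. Because compound 1 gives > 63000 nM, only a limit, the most likely outcome for compound 4 in this assay is that it too is reported only as a limit, and the step that the limit leaves unreadable from compound 1 to compound 4 is expected to be none that this assay can resolve. Compound 4 is therefore expected at 100000 nM, with a range from 30000 nM to 300000 nM.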

Compound 4, half-maximal inhibitory concentration: > 63000 nM
Compound 4: only a limit was reported; the forecaster's own chance of this, stated with the estimate: 80%; the middle value does not contradict the limit.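

In this assay compound 4 gives > 63000 nM, a limit and not a number. Compound 1 is likewise reported only as a limit, so no step can be read between compound 1 and compound 4: the limit of > 63000 nM in this assay, at which 4 of the 4 values shown sit.

The compounds shown leave open whether any member of this series has a measurable value in this assay.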